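Replacing the hydroxymethyl of compound 3 with trifluoromethyl

The source may hold more compounds than are shown below. What is called first, only, known or untested is meant among the compounds shown, and "the series" means these compounds.

The series shares a core, seen in compound 1 `O=C(Nc1ccncc1)Nc1c(Cl)cccc1Cl`, which in a functional assay on the whole organism with Mus musculus as the target, in the maximal electroshock model, with a stated time of 30 min (on this read-out higher numbers stand for an effect only at larger amounts of compound and lower numbers for an effect already at smaller amounts), gives 100 mg/kg. Compound 2 `Cc1cccc(Cl)c1NC(=O)Nc1ccncc1` gives 30 mg/kg in this assay, a step of a 3.3-fold lower number from compound 1 to compound 2 (0.52 log units; beyond the scatter). Compound 3 `O=C(Nc1ccncc1)Nc1c(Cl)cccc1CO` stands at the weak end of the numbers shown: in this assay compound 3 reaches only a limit, > 300 mg/kg, and no number. That limit sets the steps of an at least 3.0-fold higher number from compound 1 to compound 3 (0.47 log units; beyond the scatter) and an at least 10-fold higher number from compound 2 to compound 3 (1.00 log units; beyond the scatter).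

Compound 4 `O=C(Nc1ccncc1)Nc1c(Cl)cccc1C(F)(F)F` differs from compound 3 in one place: trifluoromethyl in place of hydroxymethyl on an aromatic carbon. The relevant measured steps run the other way, from the hydroxy-bearing compound 3 back toward compound 1 and compound 2, each of which gave a number where compound 3 gave only a limit (the limit of > 300 mg/kg in this assay, at which 1 of the 3 values shown sits). He therefore expects compound 4 to give a lower number than compound 3, by a step of roughly an at least 3.0-fold lower number from compound 3 to compound 4 (0.47 log units; beyond the scatter). His estimate for compound 4 in this assay is 100 mg/kg, with a range from 30 mg/kg to 300 mg/kg.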

Compound 4, minimum effective dose: 100 mg/kg
Estimate against measurement, compound 4: no gap at the digits printed, within the range that was stated.
By their numbers in this assay, from the lowest: compound 2; then compounds 1 and 4 (each within the scatter of the next). At a limit, above all of these: compound 3.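

Trifluoromethyl at this position brings back a measurable effect in this assay, with a step of an at least 3.0-fold lower number from compound 3 to compound 4 (0.47 log units; beyond the scatter), and this step is read from a limit and not from a number: the limit of > 300 mg/kg in this assay, at which 1 of the 4 values shown sits. Of the four groups seen at this position, only hydroxymethyl stays at a limit, while chloro, methyl and trifluoromethyl all give numbers. The new group is not interchangeable with methyl, as the step of a 3.3-fold higher number from compound 2 to compound 4 (0.52 log units; beyond the scatter) shows, whereas the comparison with chloro gives no change at the digits printed from compound 1 to compound 4 (within the scatter).

Going by these compounds, whether the limit belongs to the hydroxy group itself stays open: a methoxymethyl or an aminomethyl group at this position would test that. How a carboxylic acid or a longer chain would behave here also remains unknown from the compounds shown.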